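Adding a Methoxy Group: From Compound 2 to Compound 3

The source may hold more compounds than are shown below. What is called first, only, known or untested is meant among the compounds shown, and "the series" means these compounds.

The measured compounds and their values:
Compound 1 `O=C(Nc1cccc(-c2oc3cc(-c4ccc(F)cc4)ccc3c(=O)c2O)c1)c1ccc(F)cc1F`: 9640 nM
Compound 2 `COc1cccc(C(=O)Nc2cccc(-c3oc4cc(-c5ccc(F)cc5)ccc4c(=O)c3O)c2)c1`: 12500 nM

Among the measured compounds shown here, in a functional assay on GTL 16 cells for antiproliferative activity against GTL 16 cell line (Homo sapiens), read by CCK-8 assay, with a stated time of 72 h (on this read-out lower numbers stand for stronger inhibition and higher numbers for weaker inhibition), compound 2 gives 12500 nM, the highest of the two numbers so far, but its nearest neighbour is compound 1, and the step of a 1.3-fold higher number from compound 1 to compound 2 (0.11 log units; within the scatter) lies within the scatter, so the two cannot be told apart. Compound 3 `COc1cc(OC)cc(C(=O)Nc2cccc(-c3oc4cc(-c5ccc(F)cc5)ccc4c(=O)c3O)c2)c1` has not yet been measured in this assay. It differs from compound 2 by methoxy in place of hydrogen on an aromatic carbon. For the measured compounds named here, the only measured step, from compound 1 to compound 2, exchanged one aryl group on the carbonyl for another and moved the number by a 1.3-fold higher number from compound 1 to compound 2 (0.11 log units; within the scatter), which is within the scatter. That step does not probe a second methoxy group, so the data give no direct guide to the present change; they only show that varying the aryl group on the carbonyl has so far left the number about where it was. On that basis no step beyond the scatter is expected for compound 3, and the estimated step is a 1.0-fold higher number from compound 2 to compound 3 (0.02 log units; within the scatter). Compound 3 is therefore estimated at 13000 nM, with a range from 6000 nM to 28000 nM.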

Compound 3, half-maximal inhibitory concentration: 19600 nM
The estimate for compound 3 lay 1.5-fold (0.18 log units) below the measured number; the measured number falls inside the stated range.
By their numbers in this assay, from the lowest: compounds 1, 2 and 3 (each within the scatter of the next, the first and the last beyond it).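

In this assay, the new methoxy group sits meta to a methoxy group on the aryl ring of the amide, and the resulting step (a 1.6-fold higher number from compound 2 to compound 3 (0.20 log units; within the scatter)) means that compound 3 cannot be told apart from compound 2, so this single addition shows no clear effect at this position. Among the compounds shown here, the comparison with the difluorinated aryl group says a little more: replacing 2,4-difluorophenyl with 3,5-dimethoxyphenyl gives the first step beyond the scatter (a 2.0-fold higher number from compound 1 to compound 3 (0.31 log units; beyond the scatter)), although it is modest, so the choice of aryl group on the carbonyl can move the number slightly. Nothing measured here accounts for that step.

As far as these compounds go, the three compounds carry only fluoro and methoxy groups on this aryl ring, so it remains open whether an amine such as morpholine, a carboxylic acid or a longer alkoxy chain there would shift the number more strongly in either direction. From the compounds shown here alone, it is also open whether the same aryl changes would give similar steps on a different core, since all three compounds share one core.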